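Methoxy to Hydroxy on a Shared Core: Cytotoxicity

The source may hold more compounds than are shown below. What is called first, only, known or untested is meant among the compounds shown, and "the series" means these compounds.

Compound 1, `COc1ccc(/C=C2\CCC/C(=C\c3cccc(OC)c3OC)C2=O)cc1`, gives 43500 nM in an ADME assay on NHDF cells (Homo sapiens) for cytotoxicity, read by MTT assay, with a stated time of 72 h; on this read-out higher numbers stand for weaker inhibition and lower numbers for stronger inhibition.
Compound 2, `COc1cccc(/C=C2\CCC/C(=C\c3ccc(O)cc3)C2=O)c1OC`, gives only a limit of this assay, > 50000 nM, and no number.
Compound 3, `COc1cc(/C=C2\CCC/C(=C\c3ccc(OC)c(OC)c3)C2=O)ccc1O`, gives 13700 nM.

Compound 2 differs from compound 1 by hydrogen in place of methyl on an oxygen on an aromatic ring, and the step is an at least 1.1-fold higher number from compound 1 to compound 2 (0.06 log units; that floor lies within the scatter); it rests on (the limit of > 50000 nM in this assay, at which 1 of the 3 values shown sits). How the core of compound 3 differs from that of compound 1 is not broken down here; its value is the lowest of the two numbers. Compound 4, `COc1ccc(/C=C2\CCC/C(=C\c3ccc(O)c(O)c3)C2=O)cc1OC`, is not yet measured and differs from compound 3 by hydrogen in place of methyl on an oxygen on an aromatic ring, the same change. Because compound 2 sits at the limit of > 50000 nM in this assay, at which 1 of the 3 values shown sits, the earlier step gives only a floor, so compound 4 is expected to show a step of a 1.6-fold higher number from compound 3 to compound 4 (0.21 log units; within the scatter). Compound 4 is thus estimated at 22000 nM, expected between 9000 nM and 50000 nM.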

Compound 4, half-maximal inhibitory concentration: 25200 nM
For compound 4 the middle estimate is 1.1-fold (0.06 log units) below the measured one, and the stated range covers the measured number.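

In this assay, the change from methoxy to hydroxy gives a 1.8-fold higher number from compound 3 to compound 4 (0.26 log units; within the scatter), and set beside the earlier step it reads: the same change on two cores in this assay, an at least 1.1-fold higher number (0.06 log units; that floor lies within the scatter) from compound 1 to compound 2 and a 1.8-fold higher number (0.26 log units; within the scatter) from compound 3 to compound 4; the limit leaves it open whether they differ

The earlier step rests on a limit: the limit of > 50000 nM in this assay, at which 1 of the 4 values shown sits.

The new step therefore stays within the scatter, and the two cores together do not establish that the change carries from one core to another with the same size.

The aromatic rings shown carry only methoxy and hydroxy groups, so how an amine, a carboxylic acid or a fluorine atom on those rings would read in this assay remains open. Going by these compounds, whether the change from methoxy to hydroxy would read the same way on a further core also remains open.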